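The compounds below may be only part of what the source reports. "The series", "measured", "known", "first", "only" and "open" are said of these compounds alone.

Series notes. In a functional assay on the whole organism with Rattus norvegicus as the target (a higher number here means that more compound is needed for the effect, a lower number that less compound is needed), compound 1 `C[C@@H]1CC/C(=N\Nc2ccccc2)c2ncc(C(=O)O)c(=O)n21` gives 54.8 umol/kg. Compound 2 `CC1CCC(/C=N/c2ccc(C(=O)O)cc2)=C2NC=CC(=O)N21` reaches only a limit in this assay, namely > 100 umol/kg; the relevant line is the limit of > 100 umol/kg in this assay, at which 1 of the 2 values shown sits. Among the measured compounds shown here, no step between measured compounds exists, so the pair shows only a number for compound 1 against a limit for compound 2. Compound 3 `CCOC(=O)C1=CNC2=C(/C=N/c3ccc(C(=O)O)cc3)CCC(C)N2C1=O` is still unmeasured and differs from compound 2 by ethoxycarbonyl in place of hydrogen on a double-bonded ring carbon. No shown step tells how such a change moves this assay, so the direction stays open, and the expected step is an at least 1.2-fold lower number from compound 2 to compound 3 (0.09 log units; that floor lies within the scatter). For compound 3 the estimate is 80 umol/kg, spanning 25 umol/kg to 300 umol/kg, with a real chance that again only a limit is reported.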

Compound 3, dose for 50% inhibition: 67.1 umol/kg
Compound 3: the middle estimate sits 1.2-fold (0.08 log units) above what was measured, within the range that was stated.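

In this assay the series now has its first step at this position, ethoxycarbonyl in place of hydrogen on a double-bonded ring carbon: an at least 1.4-fold lower number from compound 2 to compound 3 (0.17 log units; that floor lies within the scatter). With this group, compound 3 gives a number, 67.1 umol/kg, so the position carries a substituent of this size without loss of a readable value. The step has only a floor because compound 2 stands at a limit, not a number: the limit of > 100 umol/kg in this assay, at which 1 of the 3 values shown sits.

Going by these compounds, the true size of the step stays open. So does whether a carboxylic acid, an amide or a longer chain on this ring carbon would move the number further.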